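This account rests on a few compounds, and the source may have more. Where it says the series, first, only, none or still open, it means among the compounds named here.

Compound 1 `COc1cc(/C=C2\CC/C(=C\c3ccc([N+](=O)[O-])cc3)C2=O)cc(OC)c1OC` and compound 2 `COc1cc(/C=C2\Cc3ccccc3/C(=C\c3ccc([N+](=O)[O-])cc3)C2=O)cc(OC)c1OC` share a common core and were both examined in a functional assay on HPC cells (Homo sapiens) for cytotoxicity; on this read-out higher numbers stand for lower toxicity in this test and lower numbers for higher toxicity in this test. In this assay compound 1 gives > 400000 nM, which is a limit of the test rather than a measured number. In this assay compound 2 likewise gives > 400000 nM, again a limit and not a number. Compound 2 therefore stands at the limit of > 400000 nM in this assay, at which 2 of the 2 values shown sit, so no ordering between the two can be drawn from these figures. Compound 3 `COc1ccc(/C=C2\Cc3ccccc3/C(=C\c3ccc([N+](=O)[O-])cc3)C2=O)cc1OC` differs from compound 2 by hydrogen in place of methoxy on an aromatic carbon. Within the data shown here, no step between measured compounds exists to calibrate such a change. Since compound 2 sits at the limit with > 400000 nM, the step of a number no higher from compound 2 to compound 3 (the limit leaves the size open) is expected to be none beyond the scatter. Compound 3 is thus estimated to give 400000 nM in this assay, within a range from 200000 nM to 800000 nM, with a good chance that only a limit is reported.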

Compound 3, half-maximal cytotoxic concentration: > 400000 nM
Compound 3: no number, only a limit; the forecaster's own chance of this, stated with the estimate: 80%; the middle value lies on the limit itself.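

In this assay compound 3 gives > 400000 nM, which is a limit and not a number. Among these compounds, compound 2 also stands only at a limit, so no step between compound 2 and compound 3 can be read. The compounds shown leave open whether hydrogen in place of methoxy changes the read-out at all: the limit of > 400000 nM in this assay, at which 3 of the 3 values shown sit.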